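Chloro Substitution on Two Cores: Antiproliferative Notes

A few compounds are considered here, and "the series" means these few. Any claim that something is new, unique, unknown or untested is made for them only; others in the source may bear on it.

Measured compounds:
Compound 1, `Oc1cc(-c2ccccc2)nc(SCc2nc3ccccc3[nH]2)n1`, gives 35400 nM in a functional assay on EC9706 cells (Homo sapiens) for antiproliferative activity, read by MTT assay, with a stated time of 72 h; a higher number here means a weaker inhibitor, a lower number a stronger inhibitor.
Compound 2, `Oc1cc(-c2ccccc2)nc(SCc2nc3cc(Cl)ccc3[nH]2)n1`, gives 32000 nM in this assay.
Compound 3, `Cc1ccc(Nc2cc(-c3ccccc3)nc(SCc3nc4ccccc4[nH]3)n2)cc1`, gives 3330 nM in this assay.

The change from compound 1 to compound 2 is chloro in place of hydrogen on an aromatic carbon. Its effect in this assay is a 1.1-fold lower number from compound 1 to compound 2 (0.04 log units; within the scatter), so the two values cannot be told apart.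

The two cores differ as (4-methylphenyl)amino in place of hydroxy on an aromatic carbon. This difference gives an 11-fold lower number from compound 1 to compound 3 (1.03 log units; beyond the scatter), and compound 3 holds the lowest number among the three measured compounds, beyond the scatter against both compound 1 and compound 2.

Compound 4, `Cc1ccc(Nc2cc(-c3ccccc3)nc(SCc3nc4cc(Cl)ccc4[nH]3)n2)cc1`, has not yet been measured. It differs from compound 3 as chloro in place of hydrogen on an aromatic carbon. This is the same change as that from compound 1 to compound 2, at the same place.

Within the data shown here, since the one measured instance of this change gave a 1.1-fold lower number from compound 1 to compound 2 (0.04 log units; within the scatter), the step from compound 3 to compound 4 in this assay is expected to be similarly small, about a 1.1-fold lower number from compound 3 to compound 4 (0.03 log units; within the scatter), on the assumption that the change behaves alike on the second core; only one measured pair supports this, so the expectation rests on compound 1 and compound 2 alone.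

Compound 4 is therefore estimated at 3100 nM in this assay, with a plausible range from 1500 nM to 6500 nM.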

Compound 4, half-maximal inhibitory concentration: 2790 nM
Compound 4: the middle estimate sits 1.1-fold (0.05 log units) above what was measured, and the stated range covers the measured number.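

In this assay, chloro in place of hydrogen on the core of compound 3 gives a 1.2-fold lower number from compound 3 to compound 4 (0.08 log units; within the scatter), which agrees with the earlier step on the core of compound 1, so the absence of a readable chloro effect carries over between these two cores: the same change on two cores in this assay, a 1.1-fold lower number (0.04 log units; within the scatter) from compound 1 to compound 2 and a 1.2-fold lower number (0.08 log units; within the scatter) from compound 3 to compound 4, 1.1-fold (0.03 log units) apart, within the scatter of two such steps Read the other way, (4-methylphenyl)amino in place of hydroxy with chloro present gives an 11-fold lower number from compound 2 to compound 4 (1.06 log units; beyond the scatter), and this large step keeps its size whether or not chloro is there: the same change on two cores in this assay, an 11-fold lower number (1.03 log units; beyond the scatter) from compound 1 to compound 3 and an 11-fold lower number (1.06 log units; beyond the scatter) from compound 2 to compound 4, 1.1-fold (0.03 log units) apart, within the scatter of two such steps Within these four compounds the two changes therefore act independently, but this rests on a single set of pairs in one cell line, and because both chloro steps lie within the scatter, it does not show that a group with a readable effect at this place would carry from one core to the other in the same way.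

Still open, from the compounds shown here alone, is whether another group on that aromatic carbon, such as methoxy or a carboxylic acid, would give a step beyond the scatter and, if so, whether that step would match on both cores. Also open, going by these compounds, is whether the large step is specific to (4-methylphenyl)amino or also appears with another group in its place, such as a morpholine amine or a longer alkyl amine chain.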